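Trifluoromethoxy in place of trifluoromethyl on the pendant ring

A few compounds are considered here, and "the series" means these few. Any claim that something is new, unique, unknown or untested is made for them only; others in the source may bear on it.

Four compounds share one core carrying two 2-hydroxyphenyl groups and a third aryl group that varies. In a functional assay on HCT-15 cells (Homo sapiens) for inhibition (a higher number here means a weaker inhibitor, a lower number a stronger inhibitor), compound 1 `Oc1ccccc1-c1cc(-c2ccccc2C(F)(F)F)cc(-c2ccccc2O)n1` gives 3970 nM. Compound 3 `Oc1ccccc1-c1cc(-c2ccccc2OC(F)(F)F)cc(-c2ccccc2O)n1` gives 4520 nM in this assay. The difference between these two is trifluoromethoxy in place of trifluoromethyl on an aromatic carbon, and that change made a 1.1-fold higher number from compound 1 to compound 3 (0.06 log units; within the scatter).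

Compound 2 `Oc1ccccc1-c1cc(-c2cccc(C(F)(F)F)c2)cc(-c2ccccc2O)n1` differs from compound 1 in its core as follows: 3-(trifluoromethyl)phenyl in place of 2-(trifluoromethyl)phenyl on an aromatic carbon. Across that difference an at least 12-fold higher number from compound 1 to compound 2 (1.10 log units; beyond the scatter). In this assay compound 2 gives > 50000 nM, which is a limit of the assay and not a number, namely (the limit of > 50000 nM in this assay, at which 1 of the 3 values shown sits).

Compound 4 `Oc1ccccc1-c1cc(-c2cccc(OC(F)(F)F)c2)cc(-c2ccccc2O)n1` is not yet measured in this assay. It differs from compound 2 as follows: trifluoromethoxy in place of trifluoromethyl on an aromatic carbon. Going by the values given here, this is the same kind of change as the one from compound 1 to compound 3, not the same one, since there the place was ortho to a large group and here it is meta to a large group.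

Because the earlier instance of this kind of change made a 1.1-fold higher number from compound 1 to compound 3 (0.06 log units; within the scatter), compound 4 is expected to give 60000 nM. For compound 4 the expected range runs from 20000 nM to 200000 nM, which means an expected step that the limit leaves unreadable from compound 2 to compound 4, and a result that is again only a limit is considered likely.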

Compound 4, half-maximal inhibitory concentration: > 50000 nM
Compound 4: no number, only a limit (the forecaster's own chance of this, stated with the estimate: 75%); the middle value is on the limit's open side.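

In this assay compound 4 gives > 50000 nM, which is a limit of the assay and not a number. Compound 2 also stands at a limit, so no step can be read between compound 2 and compound 4: the limit of > 50000 nM in this assay, at which 2 of the 4 values shown sit. The compounds shown leave open whether trifluoromethoxy in place of trifluoromethyl changes the value at all when the group sits meta to a large group.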